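The compounds below may be only part of what the source reports. "The series", "measured", "known", "first", "only" and "open" are said of these compounds alone.

Measured so far in an assay on HEK293 cells for displacement of a labelled ligand from 5-hydroxytryptamine receptor 6 (Homo sapiens), read by scintillation counting; on this read-out higher numbers stand for weaker inhibition and lower numbers for stronger inhibition:
- compound 1, `O=S(=O)(c1cnc2ccccc2c1)n1cc(C2=CCNCC2)c2ccccc21`: 13 nM
- compound 2, `O=S(=O)(c1ccc2cccnc2c1)n1cc(C2=CCNCC2)c2ccccc21`: 7 nM
- compound 3, `O=S(=O)(c1cccc2ncccc12)n1cc(C2=CCNCC2)c2cc(Cl)ccc21`: 11 nM

Compound 3 sits among the three numbers with no separation that counts: its value and that of compound 1 lie close together, and even its gap to compound 2 stays inside the usual scatter of repeated measurements. On the numbers shown, then, the three compounds are indistinguishable in this assay.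

The next compound, compound 4, `COc1ccc2c(c1)c(C1=CCNCC1)cn2S(=O)(=O)c1cccc2ncccc12`, keeps the whole of compound 3 except for one substituent on its core: methoxy in place of chloro on an aromatic carbon. Among the compounds with values here, no pair of measured compounds differs in this way, so nothing measured here tells directly how such an exchange plays out in this assay.

What the shown compounds do tell is that changes at the periphery of this shared core have so far left the inhibition constant essentially unmoved. On that basis compound 4 is expected to stay close to compound 3, with a step of a 1.4-fold lower number from compound 3 to compound 4 (0.14 log units; within the scatter) that need not reach beyond the scatter. The estimate for compound 4 in this assay is therefore 8 nM, with a likely range from 3 nM to 25 nM.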

Compound 4, inhibition constant: 4 nM
For compound 4 the middle estimate is 2.0-fold (0.30 log units) above the measured one; measured number inside the range.
By their numbers in this assay, from the lowest: compounds 4, 2, 3 and 1 (each within the scatter of the next, the first and the last beyond it).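

In this assay the exchange of chloro for methoxy on this aromatic carbon of the shared core gives a 2.8-fold lower number from compound 3 to compound 4 (0.44 log units; beyond the scatter) and so separates two compounds by more than the scatter, though only modestly. Within the data shown here, this is the first indication that this position, meta to one fused ring and para to another, is not indifferent to what it carries, which the earlier comparisons among compounds differing in more than one place could not show. The exchange also brings in a hydrogen-bond acceptor, but nothing shown ties the step to that acceptor or to any other measured property of either group.

Among these compounds, with only this single pair, it stays open whether the oxygen, the added carbon or the loss of chloro goes with the lower number, and hydroxy, ethoxy, fluoro or an amine on the same carbon would begin to separate these. From the compounds shown here alone, it also stays open whether the same exchange would give a similar step with the differently attached sulfonyl groups of compound 1 and compound 2.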